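The compounds below may be only part of what the source reports. "The series", "measured", "known", "first", "only" and "open" are said of these compounds alone.

Compound 1 `C/C(=N\CC(C)C)c1c(O)c2ccccc2oc1=O` gives 34000 nM in an assay on isolated protein for inhibition of myosin-2 (Bos taurus), read by spectrophotometry, with a stated time of 24 min; a higher number here means a weaker inhibitor, a lower number a stronger inhibitor.
Compound 2 `C/C(=N\CCO)c1c(O)c2ccccc2oc1=O` gives 92000 nM in this assay.
Compound 3 `C/C(=N\Cc1cccc(C)c1)c1c(O)c2ccccc2oc1=O` gives 4900 nM in this assay.

Compound 3 has the lowest number of the three; the steps of a 6.9-fold lower number from compound 1 to compound 3 (0.84 log units; beyond the scatter) and a 19-fold lower number from compound 2 to compound 3 (1.27 log units; beyond the scatter) both lie beyond the scatter, so it is the strongest inhibitor of this set. Compound 4 `C/C(=N\Cc1cccnc1)c1c(O)c2ccccc2oc1=O` differs from it by pyridin-3-yl in place of 3-methylphenyl on a saturated chain carbon bound to a double-bonded nitrogen. Among the compounds with values here, no measured step exchanges one aromatic ring for another. Within the data shown here, the measured steps show only that an aromatic ring on this carbon gave a lower number than isopropyl or hydroxymethyl, as in a 6.9-fold lower number from compound 1 to compound 3 (0.84 log units; beyond the scatter) and a 19-fold lower number from compound 2 to compound 3 (1.27 log units; beyond the scatter). Since compound 4 keeps an aromatic ring, only a small rise in number is expected in this assay, near the edge of the scatter, as a 2.4-fold higher number from compound 3 to compound 4 (0.39 log units; beyond the scatter). Compound 4 is estimated at 12000 nM, with a range from 4000 nM to 35000 nM.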

Compound 4, half-maximal inhibitory concentration: 17000 nM
Estimate against measurement, compound 4: 1.4-fold (0.15 log units) below; the range from low to high includes it.
By their numbers in this assay, from the lowest: compound 3; then compounds 4 and 1 (each within the scatter of the next); then compound 2.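

In this assay, exchanging one aromatic ring for another on this carbon is itself a step beyond the scatter (a 3.5-fold higher number from compound 3 to compound 4 (0.54 log units; beyond the scatter)), so an aromatic ring alone does not secure the number of compound 3. Pyridin-3-yl still stands clear of hydroxymethyl (a 5.4-fold lower number from compound 2 to compound 4 (0.73 log units; beyond the scatter)), but it is not separated from isopropyl (a 2.0-fold lower number from compound 1 to compound 4 (0.30 log units; within the scatter)). No evidence at hand accounts for these steps. The compounds shown leave open where a plain phenyl ring would stand, which would separate the methyl from the ring nitrogen. As far as these compounds go, how a carboxylic acid on this carbon would read also remains open.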